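A few compounds are considered here, and "the series" means these few. Any claim that something is new, unique, unknown or untested is made for them only; others in the source may bear on it.

Among the compounds with values here, compound 1 `N#Cc1c(NN)nc(SCc2nc3ccccc3[nH]2)nc1-c1ccccc1` gives 14.7 nM in a functional assay on K562 cells (Homo sapiens) for cytotoxicity, read by MTT assay, with a stated time of 3 days (a higher number here means a weaker inhibitor, a lower number a stronger inhibitor), the higher of the two numbers measured so far. Compound 2 `N#Cc1c(Nc2ccccn2)nc(SCc2nc3ccccc3[nH]2)nc1-c1ccccc1` gives 7 nM in this assay, and the step of a 2.1-fold lower number from compound 1 to compound 2 (0.32 log units; beyond the scatter) is the only one known. Compound 3 `N#Cc1c(Nc2nccs2)nc(SCc2nc3ccccc3[nH]2)nc1-c1ccccc1` differs from compound 1 by 1,3-thiazol-2-yl in place of amino on a nitrogen on an aromatic ring. Since the step to compound 2 also replaced the amino with an aromatic ring on that nitrogen and lowered the number modestly, a step of similar size and direction is expected here, a 1.8-fold lower number from compound 1 to compound 3 (0.26 log units; within the scatter). Compound 3 is therefore estimated to give 8 nM in this assay, within a range from 4 nM to 17 nM.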

Compound 3, half-maximal inhibitory concentration: 14.7 nM
Compound 3: middle estimate off by 1.8-fold (0.26 log units), on the low side, and the stated range covers the measured number.
By their numbers in this assay, from the lowest: compound 2; then compounds 1 and 3 (each within the scatter of the next).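

Placing an aromatic ring on this nitrogen does not by itself lower the number: 1,3-thiazol-2-yl in place of amino gives no gain (no change at the digits printed from compound 1 to compound 3 (within the scatter)). The identity of the ring counts at this position, as 1,3-thiazol-2-yl in place of pyridin-2-yl separates the two ring-bearing compounds (a 2.1-fold higher number from compound 2 to compound 3 (0.32 log units; beyond the scatter)). No measurement available here accounts for this difference between the two rings. From the compounds shown here alone, it remains open how phenyl or a small chain such as methyl on this nitrogen would compare with pyridin-2-yl. Going by these compounds, all three compounds share the same core, so whether these steps hold with other groups on it also remains open.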